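The source may report more compounds than this note shows. Statements on the series, on what has been measured and on what is new or still open speak of the compounds shown alone.

In an assay on CHO cells with G-protein coupled receptor 39 (Homo sapiens) as the target, read by calcium flux (a lower number here means that less compound is needed, a higher number that more compound is needed for the effect), compound 1 `Cc1cc(N2CCCC2c2ccccc2)n2ncc(-c3ccccn3)c2n1` reaches only a limit of the assay, > 27100 nM. In this assay compound 2 `CNc1nc(Oc2ccccc2)cc(-c2ccccn2)n1` gives 23 nM, the only number shown among the two values. The other value belongs to compound 1 and is a limit of the assay, (the limit of > 27100 nM in this assay, at which 1 of the 2 values shown sits). Compound 2 therefore has no measured neighbour against which its number can be ranked. Compound 3 `CNc1nc(NC2CCCCC2)cc(-c2ccccn2)n1` differs from compound 2 in one place: cyclohexylamino in place of phenoxy on an aromatic carbon. Within the data shown here, no step between two measured compounds resembles this exchange, so the expectation rests on compound 2 alone. One would expect the exchange to cost some potency, a step somewhat beyond the scatter rather than a large one, the expected step being a 2.6-fold higher number from compound 2 to compound 3 (0.42 log units; beyond the scatter). Compound 3 is accordingly estimated at 60 nM, with a likely range from 15 nM to 250 nM.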

Compound 3, half-maximal effective concentration: > 27100 nM
Compound 3: no number, only a limit; the forecaster's own chance of this, stated with the estimate: 5%; middle value at least 450-fold (2.65 log units) away from the limit.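

This position on the shared core therefore tolerates far less than compound 2 alone could show. In this assay, the exchange of phenoxy for cyclohexylamino gives an at least 1100-fold higher number from compound 2 to compound 3 (3.07 log units; beyond the scatter). The two groups both carry a six-membered ring of carbon only, but the ring is aromatic in phenoxy and non-aromatic in cyclohexylamino, and an oxygen gives way to a nitrogen that brings a hydrogen-bond donor. Compound 3 gives only a limit of the assay, not a number: the limit of > 27100 nM in this assay, at which 2 of the 3 values shown sit.

The compounds shown leave open whether the loss follows the ring or the linking atom, since both change in this one step. A phenylamino group or a cyclohexyloxy group on this aromatic carbon would separate the two.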